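Heptyl for chloropyrazolyl on the amide: lipophilicity expected to rise

This account rests on a few compounds, and the source may have more. Where it says the series, first, only, none or still open, it means among the compounds named here.

Compound 1 `CC[C@H]1OC(=O)[C@H](C)[C@@H](O[C@H]2C[C@@](C)(OC)[C@@H](O)[C@H](C)O2)[C@H](C)[C@@H](O[C@@H]2O[C@H](C)C[C@H](N(C)C)[C@H]2O)[C@](C)(O)C[C@@H](C)CN(CCCNC(=O)c2c(C)nn(C)c2Cl)[C@H](C)[C@@H](O)[C@]1(C)O` — 2.2
Compound 2 `CC[C@H]1OC(=O)[C@H](C)[C@@H](O[C@H]2C[C@@](C)(OC)[C@@H](O)[C@H](C)O2)[C@H](C)[C@@H](O[C@@H]2O[C@H](C)C[C@H](N(C)C)[C@H]2O)[C@](C)(O)C[C@@H](C)CN(C)[C@H](C)[C@@H](OCCCNC(=O)c2c(C)nn(C)c2Cl)[C@]1(C)O` — 3.01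
Compound 3 `CCCCC(=O)NCCCN1C[C@H](C)C[C@@](C)(O)[C@H](O[C@@H]2O[C@H](C)C[C@H](N(C)C)[C@H]2O)[C@@H](C)[C@H](O[C@H]2C[C@@](C)(OC)[C@@H](O)[C@H](C)O2)[C@@H](C)C(=O)O[C@H](CC)[C@@](C)(O)[C@H](O)[C@H]1C` — 2.72

In a physicochemical assay for lipophilicity, read by HPLC, measured as chromatographic lipophilicity, at pH 7.4 (a higher number here means a more lipophilic compound, a lower number a more polar compound), compound 2 gives 3.01. Compound 3 gives 2.72, a number within the scatter of that of compound 2. Compound 1 gives 2.2, which lies beyond the scatter below compound 2.

Compound 4 `CCCCCCCC(=O)NCCCO[C@@H]1[C@@H](C)N(C)C[C@H](C)C[C@@](C)(O)[C@H](O[C@@H]2O[C@H](C)C[C@H](N(C)C)[C@H]2O)[C@@H](C)[C@H](O[C@H]2C[C@@](C)(OC)[C@@H](O)[C@H](C)O2)[C@@H](C)C(=O)O[C@H](CC)[C@@]1(C)O` is not yet measured. It differs from compound 2 in one place: heptyl in place of 5-chloro-1,3-dimethyl-1H-pyrazol-4-yl on a carbonyl carbon.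

Among the measured compounds shown here, one measured step bears on this change. It is a number 0.52 log units higher from compound 1 to compound 3 (beyond the scatter), where the same pyrazolyl group left the carbonyl carbon and butyl entered. Heptyl is a longer chain than butyl, so a larger rise than that step is expected here. For compound 4 the expected step is a number 1.69 log units higher from compound 2 to compound 4 (beyond the scatter) in this assay. Compound 4 is therefore estimated at 4.7 in this assay, with a range from 4 to 5.4.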

Compound 4, distribution coefficient: 5.18
The estimate for compound 4 lay 0.48 log units below the measured number, and the stated range covers the measured number.
By their numbers in this assay, from the lowest: compound 1; then compounds 3 and 2 (each within the scatter of the next); then compound 4.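

In this assay, among the compounds shown here, heptyl on this carbonyl carbon gives a number 2.17 log units higher from compound 2 to compound 4 (beyond the scatter), a large step for the change away from 5-chloro-1,3-dimethyl-1H-pyrazol-4-yl, where the earlier compounds offered only the modest a number 0.52 log units higher from compound 1 to compound 3 (beyond the scatter) with butyl as the entering group. The two steps differ both in the entering chain and in the compound that carries it, so their difference in size cannot be assigned to chain length alone. Nothing measured here accounts for the size of the new step.

Open, going by these compounds, is how butyl would read on the carbonyl carbon of compound 2 and how heptyl would read on that of compound 1, either of which would separate these two differences. Also open, on these data alone, is how a heptyl chain ending in an amine or a carboxylic acid would read at this place.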